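The source may report more compounds than this note shows. Statements on the series, on what has been measured and on what is new or still open speak of the compounds shown alone.

Measured so far in a functional assay on HT29-AK cells (Homo sapiens) for cytotoxicity, read by MTT assay, with a stated time of 48 h; a lower number here means a stronger inhibitor, a higher number a weaker inhibitor:
compound 1 `Fc1cccc(-c2nc(Nc3ccccc3)c3ccccc3n2)c1`: > 50000 nM (a limit, not a number)
compound 2 `Fc1ccc2nc(-c3ccccc3)nc(Nc3ccccc3)c2c1`: > 50000 nM (a limit, not a number)
compound 3 `COc1ccc(Nc2nc(-c3cccc(F)c3)nc3ccc(F)cc23)cc1`: 42300 nM

Within the data shown here, compound 3, at 42300 nM, is the only compound with an actual number, which makes it the single reference point in this assay. The other two entries give no size of difference from compound 3. The series as a whole lies close to the limit of > 50000 nM in this assay, at which 2 of the 3 values shown sit.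

Next to be read is compound 4 `Fc1ccc(Nc2nc(-c3cccc(F)c3)nc3ccc(F)cc23)cc1`. It differs from compound 3 in one place: fluoro in place of methoxy on an aromatic carbon. This is fluoro in place of methoxy on an aromatic carbon, para to a large group; cut one bond further out, it reads 4-methoxyphenyl to 4-fluorophenyl.

Among the measured compounds shown here, no measured pair isolates this change, so the expectation rests on compound 3 alone. The expectation starts from compound 3 at 42300 nM. A report of only a limit is a real possibility for compound 4. The estimated 1.1-fold higher number from compound 3 to compound 4 (0.03 log units; within the scatter) is small, with no change beyond the scatter expected. For compound 4 the expected value is 45000 nM, with an estimated range of 20000 nM to 50000 nM.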

Compound 4, half-maximal inhibitory concentration: > 50000 nM
Compound 4 ended at the assay's limit; the forecaster's own chance of this, stated with the estimate: 50%; middle value at least 1.1-fold (0.04 log units) away from the limit.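

In this assay, among these compounds, compound 3 and compound 4 form the first pair that differs in one place, and the change from 4-methoxyphenyl to 4-fluorophenyl reads as an at least 1.1-fold higher number from compound 3 to compound 4 (0.07 log units; that floor lies within the scatter). Compound 4 gives > 50000 nM, which is a limit and not a number, so this step has only a floor, and that floor lies within the scatter. What this position now shows is that fluoro on this aromatic carbon yields no measurable number, leaving methoxy as the only group shown here with one, and the series stays at the top of its range: the limit of > 50000 nM in this assay, at which 3 of the 4 values shown sit.

As far as these compounds go, the true size of the step stays unknown, and so it remains open whether methoxy differs from fluoro here by more than the scatter or whether the number for compound 3 merely sits close to the limit. Also open, from the compounds shown here alone, is whether an amine or a carboxylic acid on the same aromatic carbon, or a longer chain such as butoxy, would give a number clearly away from the limit.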